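This account rests on a few compounds, and the source may have more. Where it says the series, first, only, none or still open, it means among the compounds named here.

In a functional assay on OVCAR-3 cells (Homo sapiens) for antiproliferative activity, read by MTT assay, with a stated time of 24 h (a higher number here means a weaker inhibitor, a lower number a stronger inhibitor), compound 3 (`CCCCOc1ccc(C(=O)NNC(=O)c2ccccc2NS(=O)(=O)c2cnc(O)nc2O)cc1`) gives 5010 nM. That value lies within the scatter of compound 2 (`O=C(NNc1cccc(Cl)c1)c1ccccc1NS(=O)(=O)c1cnc(O)nc1O`), which gives 5520 nM. It also lies beyond the scatter of compound 1 (`O=C(NNc1ccccc1Cl)c1ccccc1NS(=O)(=O)c1cnc(O)nc1O`), which gives 14100 nM. Compound 4 (`O=C(NNC(=O)c1ccccc1NS(=O)(=O)c1cnc(O)nc1O)c1ccccc1F`) carries 2-fluorophenyl in place of 4-butoxyphenyl on a carbonyl carbon, and the change is 2-fluorophenyl in place of 4-butoxyphenyl on a carbonyl carbon.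

Among the compounds with values here, only one measured step bears on this change, and only indirectly. It is a 2.6-fold lower number from compound 1 to compound 2 (0.41 log units; beyond the scatter), a modest step with 3-chlorophenyl in place of 2-chlorophenyl on an amine nitrogen. Within the data shown here, no measured step removes 4-butoxyphenyl, and none changes a group on a carbonyl carbon. Among the measured compounds shown here, the one hint is that compound 1, the only measured compound with a 2-substituted phenyl group, has the highest number, 14100 nM. On that thin evidence, a small move toward a higher number is expected in this assay, no larger than the measured step and possibly not beyond the scatter. The expected change is a 1.6-fold higher number from compound 3 to compound 4 (0.20 log units; within the scatter). For compound 4 the estimated value is 8000 nM, with an expected range of 3000 nM to 20000 nM.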

Compound 4, half-maximal inhibitory concentration: 15300 nM
Estimate against measurement, compound 4: 1.9-fold (0.28 log units) below, within the range that was stated.
By their numbers in this assay, from the lowest: compounds 3 and 2 (each within the scatter of the next); then compounds 1 and 4 (each within the scatter of the next).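

In this assay, within the data shown here, the change on the carbonyl carbon gives a 3.1-fold higher number from compound 3 to compound 4 (0.48 log units; beyond the scatter) and so shows for the first time that the group at this place bears on the number, with 2-fluorophenyl giving a weaker result than 4-butoxyphenyl. Compound 4 also separates from the 3-chlorophenyl compound, with a 2.8-fold higher number from compound 2 to compound 4 (0.44 log units; beyond the scatter) as the step, while a 1.1-fold higher number from compound 1 to compound 4 (0.04 log units; within the scatter) is a step from which no difference can be read, so (2-fluorophenyl)carbonyl and 2-chlorophenyl on the amine nitrogen stand level. Among these four compounds, the two carrying 2-chlorophenyl or 2-fluorophenyl share the higher numbers, with no compound going against this, although the two groups are attached differently and nothing shown gives a reason for the result.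

The compounds shown leave open whether the higher number of compound 4 goes with the loss of the butoxy chain or with the entry of fluorine at this place. Plain phenyl, 4-fluorophenyl or 4-methoxyphenyl on the same carbonyl carbon would separate these two readings, and a longer chain than butoxy would show whether the number keeps falling as the chain grows.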